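This account rests on a few compounds, and the source may have more. Where it says the series, first, only, none or still open, it means among the compounds named here.

Compound 2 `CN1C/C(=C\c2cccnc2)C(=O)/C(=C/c2ccccc2C(F)(F)F)C1` and compound 1 `CN1C/C(=C\c2cccnc2)C(=O)/C(=C/c2ccccc2F)C1` share one core. In a functional assay on QGY-7703 cells (Homo sapiens) for cytotoxicity, read by MTT assay, with a stated time of 24 h (a lower number here means a stronger inhibitor, a higher number a weaker inhibitor), compound 2 gives 2910 nM, and compound 1 gives 4470 nM. The change between them is fluoro in place of trifluoromethyl on an aromatic carbon, which made a 1.5-fold higher number from compound 2 to compound 1 (0.19 log units; within the scatter). Compound 3 `O=C1/C(=C/c2ccncc2)CN(S(=O)(=O)c2ccc(C(F)(F)F)cc2)C/C1=C\c1ccccc1F` has a different core, and the difference between the two cores is not broken down here. In this assay compound 3 gives 9500 nM. Compound 4 `O=C1/C(=C/c2ccncc2)CN(S(=O)(=O)c2ccc(F)cc2)C/C1=C\c1ccccc1F` has not been measured. For the measured compounds named here, it differs from compound 3 by fluoro in place of trifluoromethyl on an aromatic carbon, the same kind of change as the one between compound 2 and compound 1, but here the place is para to a large group rather than ortho to a large group. Because the earlier step of a 1.5-fold higher number from compound 2 to compound 1 (0.19 log units; within the scatter) stayed within the scatter, a similarly small step is expected here, a 1.3-fold higher number from compound 3 to compound 4 (0.10 log units; within the scatter). Compound 4 is expected to give about 12000 nM, within 6000 nM to 25000 nM.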

Compound 4, half-maximal inhibitory concentration: 9100 nM
For compound 4 the middle estimate is 1.3-fold (0.12 log units) above the measured one; low and high end bracket the measured number.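

In this assay, replacing trifluoromethyl with fluoro on the core of compound 3 gives a 1.0-fold lower number from compound 3 to compound 4 (0.02 log units; within the scatter). The two available steps for this change agree, so in this series the swap carries from one core to the other without a readable difference: the same change on two cores in this assay, a 1.5-fold higher number (0.19 log units; within the scatter) from compound 2 to compound 1 and a 1.0-fold lower number (0.02 log units; within the scatter) from compound 3 to compound 4, 1.6-fold (0.21 log units) apart, within the scatter of two such steps. For the compounds shown here, this rests on only two pairs, with the change at a different place in each, and it does not show that the same would hold on any further core.

The compounds shown carry only fluoro and trifluoromethyl at these places, so the result of an amine or a carboxylic acid there remains open. No pair shown separates the parts in which the two cores differ, so their individual contributions also remain open.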